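The source may report more compounds than this note shows. Statements on the series, on what has been measured and on what is new or still open speak of the compounds shown alone.

Values in a functional assay on A549 cells (Homo sapiens) for antiproliferative activity, read by MTT assay; on this read-out lower numbers stand for stronger inhibition and higher numbers for weaker inhibition:
Compound 1 `Cn1c(=O)c(=O)n(C2CCCC2)c2nc(N/N=C/c3ccc(Cl)cc3)ncc21`: 6890 nM
Compound 2 `Cn1c(=O)c(=O)n(C2CCCC2)c2nc(N/N=C/c3ccc(S(C)(=O)=O)cc3)ncc21`: 84500 nM
Compound 3 `Cn1c(=O)c(=O)n(C2CCCC2)c2nc(N/N=C/c3cccc(O)c3)ncc21`: only a limit of the assay, > 100000 nM

Compound 1 gives the lowest of the two numbers available; compound 2 is the nearest, at a 12-fold higher number from compound 1 to compound 2 (1.09 log units; beyond the scatter). Compound 3 sits at the assay limit (the limit of > 100000 nM in this assay, at which 1 of the 3 values shown sits). The step of an at least 14-fold higher number from compound 1 to compound 3 (1.16 log units; beyond the scatter) is thus only a floor. Compound 4 `Cn1c(=O)c(=O)n(C2CCCC2)c2nc(N/N=C/c3ccc(F)cc3F)ncc21` carries 2,4-difluorophenyl in place of 4-chlorophenyl on a carbon with a double bond to nitrogen. Both measured steps put methylsulfonyl or 3-hydroxyphenyl in for the chloro, whereas compound 4 keeps a halogen-bearing ring, so neither step transfers directly. No step beyond the scatter is expected, at most a small drift upward, a 1.3-fold higher number from compound 1 to compound 4 (0.12 log units; within the scatter). Compound 4 is therefore estimated at 9000 nM, range 3000 nM to 30000 nM.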

Compound 4, half-maximal inhibitory concentration: 18300 nM
Compound 4: middle estimate off by 2.0-fold (0.31 log units), on the low side, within the range that was stated.
By their numbers in this assay, from the lowest: compound 1; then compound 4; then compound 2. At a limit, above all of these: compound 3.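

The step of a 2.7-fold higher number from compound 1 to compound 4 (0.42 log units; beyond the scatter) shows that this position is sensitive even when the replacement ring carries only halogen, so halogen alone does not preserve the number of compound 1. With a 4.6-fold lower number from compound 2 to compound 4 (0.66 log units; beyond the scatter) stated for the change from 4-(methylsulfonyl)phenyl, the 2,4-difluorophenyl ring still gives the lower number. Compound 3 is a limit of the assay, so an at least 5.4-fold lower number from compound 3 to compound 4 (0.73 log units; beyond the scatter) stands only as a floor: the limit of > 100000 nM in this assay, at which 1 of the 4 values shown sits.

The compounds shown do not separate the change of halogen from the added fluorine, which a 4-fluorophenyl group would address. From the compounds shown here alone, how a 4-aminophenyl or 4-carboxyphenyl group would read on this carbon also stays open.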